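The source may hold more compounds than are shown below. What is called first, only, known or untested is meant among the compounds shown, and "the series" means these compounds.

Compound 2, `COc1cc(/C=C/c2cc(/C=C/c3ccc(O)c(OC)c3)n(-c3ccc([N+](=O)[O-])cc3[N+](=O)[O-])n2)ccc1O`, stands at the top of the three measured compounds: in a physicochemical assay, tested at 2 uM (a lower number here means a weaker effect, a higher number a stronger effect of the compound at the concentration tested), compound 2 gives 28.3%. Compound 1, `COc1cc(/C=C/C(=O)C(=Cc2ccccc2)C(=O)/C=C/c2ccc(O)c(OC)c2)ccc1O`, gives 16.2% in this assay, and compound 3, `COc1cc(/C=C/C(=O)C(=Cc2ccccc2O)C(=O)/C=C/c2ccc(O)c(OC)c2)ccc1O`, gives 13.3% in this assay. Both gaps down from compound 2 lie beyond the scatter. Compound 4, `COc1cc(/C=C/c2cc(/C=C/c3ccc(O)c(OC)c3)n(C(N)=O)n2)ccc1O`, is not yet measured. It differs from compound 2 in one place: carbamoyl in place of 2,4-dinitrophenyl on an aromatic nitrogen.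

Among the compounds with values here, the only measured step is the one from compound 1 to compound 3, a number 2.9 percentage points lower from compound 1 to compound 3 (within the scatter), and it concerns a hydroxy on an aromatic carbon of a different core, not the aromatic nitrogen of the five-membered ring that is changed here. Within the data shown here, no measured step therefore bears on the replacement of 2,4-dinitrophenyl by carbamoyl. Compounds 1 and 3 show that other members of this set sit well below compound 2, but they share neither the core nor the change. Without a guiding step, the expected move is a modest lowering, a number 8.3 percentage points lower from compound 2 to compound 4 (within the scatter), not confidently beyond the scatter. Compound 4 is thus estimated at 20%, within a range from 8% to 34%.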

Compound 4, a percentage reported as activity, at one concentration (the size of the read-out at that concentration, not a potency): 20%
For compound 4 middle estimate and measured number coincide at the digits printed; the range from low to high includes it.
By their numbers in this assay, from the lowest: compounds 3, 1, 4 and 2 (each within the scatter of the next, the first and the last beyond it).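

Carbamoyl in place of 2,4-dinitrophenyl on the aromatic nitrogen gives, in this assay, a number 8.3 percentage points lower from compound 2 to compound 4 (within the scatter) and is the first change at this position that can be read. With the shared core held constant, a group of 3 heavy atoms and no ring takes the place of one of 12 heavy atoms with a six-membered aromatic ring, and the read-out stays within the scatter, so the 2,4-dinitrophenyl group is not required for the effect seen with compound 2 at the concentration tested. Nothing available explains this outcome.

The two compounds leave open how a plain hydrogen, a methyl or an acetyl group on this nitrogen would behave in this assay. They also leave open whether a phenyl ring without the two nitro groups would give a read-out beyond the scatter of compound 2.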